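Swapping tert-butyl for 1,3,4-thiadiazol-2-yl on an amide

A few compounds are considered here, and "the series" means these few. Any claim that something is new, unique, unknown or untested is made for them only; others in the source may bear on it.

Three compounds share a core built around a chlorophenyl group; all were tested in a functional assay on CHO cells for agonist activity at Free fatty acid receptor 2 (Homo sapiens), read by cAMP accumulation; a higher number here means a larger maximal response, a lower number a smaller maximal response. Compound 1, `CC(C)C(c1ccc(Cl)cc1)S(=O)(=O)Nc1nccs1`, carries a sulfonamide linked to a thiazole, and in this assay compound 1 reaches only the assay limit of < 30%. Compound 2, `CC(C)C(C(N)=O)c1ccc(Cl)cc1`, is a simple primary amide, and compound 2 likewise gives only the limit of < 30%. Compound 3, `CC(C)[C@H](C(=O)NC(C)(C)C)c1ccc(Cl)cc1`, has a tert-butyl group on the amide nitrogen, and compound 3 also returns just the limit of < 30%. Compound 3 thus stands at the same floor as the other two, as summarised by the limit of < 30% in this assay, at which 3 of the 3 values shown sit: none of the three gives a measurable maximal response.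

Compound 4, `CC(C)[C@H](C(=O)Nc1nncs1)c1ccc(Cl)cc1`, has not been measured. It differs from compound 3 by 1,3,4-thiadiazol-2-yl in place of tert-butyl on an amide-type nitrogen. For the measured compounds named here, no step between measured compounds is known, so the size of this change can only be guessed. A step upward from the limit is expected, from compound 3 to compound 4 estimated at a number at least 15 percentage points higher from compound 3 to compound 4 (beyond the scatter), though a result staying at the limit remains quite possible. For compound 4 the expected value in this assay is 45%, with a range from 20% to 80%.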

Compound 4, largest response reached (reported as efficacy), in percent of the reference or control that the assay uses: 115%
Estimate against measurement, compound 4: 70 percentage points below; measured number outside the range, above it.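

In this assay the swap of tert-butyl for 1,3,4-thiadiazol-2-yl on the amide-type nitrogen gives a number at least 85 percentage points higher from compound 3 to compound 4 (beyond the scatter) and so shows that the group on this nitrogen can decide whether the shared core produces a measurable maximal response at all. The earlier compounds shown here could not reveal this, as they offered no number to compare and compound 4 is the only one to rise clear of the assay limit: the limit of < 30% in this assay, at which 3 of the 4 values shown sit. The change brings in one five-membered aromatic ring with 3 hetero atoms and 3 hydrogen-bond acceptors where tert-butyl had no ring and no acceptor, but this single pair cannot tell which of these features matters.

Going by these compounds, it remains open whether the ring as such or its particular nitrogen and sulfur atoms carry the response, a question that a plain phenyl, a pyridin-2-yl or a thiazol-2-yl group on the same amide nitrogen would address. Equally open, on these data alone, is how the response changes when the chlorine of the shared core gives way to a methyl or a methoxy group while the 1,3,4-thiadiazol-2-yl stays in place.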